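The source may hold more compounds than are shown below. What is called first, only, known or untested is meant among the compounds shown, and "the series" means these compounds.

Measured so far in a functional assay on K562 cells (Homo sapiens) for inhibition, read by MTT assay, with a stated time of 72 h; on this read-out higher numbers stand for weaker inhibition and lower numbers for stronger inhibition:
- compound 1 `CCOC(=O)C1=C(Nc2ccccc2)S/C(=C\c2ccc(O)c(O)c2)C1=O`: 5200 nM
- compound 2 `CCOC(=O)C1=C(Nc2ccccc2)S/C(=C\c2ccc([N+](=O)[O-])c(O)c2)C1=O`: 12700 nM

Within the data shown here, compound 1 stands lowest of the two measured compounds, and compound 2 is its only neighbour on the numbers. Next in the series is compound 3 `CCOC(=O)C1=C(Nc2ccccc2)S/C(=C\c2cc3cccnc3[nH]2)C1=O`, which keeps the shared core but exchanges the whole aromatic group: a group of 9 heavy atoms (7 carbon, 2 nitrogen; one five-membered aromatic ring with 1 hetero atom, one six-membered aromatic ring with 1 hetero atom) in place of a group of 8 heavy atoms (6 carbon, 2 oxygen; one six-membered aromatic ring of carbon only), on a double-bonded chain carbon bound to a double-bonded ring carbon. The 3,4-dihydroxyphenyl leaves entirely, so this is a larger change than any yet measured.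

Among the measured compounds shown here, only one measured step bears on it, and only loosely: a 2.4-fold higher number from compound 1 to compound 2 (0.39 log units; beyond the scatter). That step put nitro in place of hydroxy on an aromatic carbon, and it was modest but beyond the scatter. For the measured compounds named here, no measured compound yet shows what replacing the entire group does. Going by the values given here, the single change made to this group so far raised the number, so a modest move in the same direction is expected in this assay, with wide uncertainty. The expected step is a 1.7-fold higher number from compound 1 to compound 3 (0.24 log units; within the scatter). For compound 3 the estimate is 9000 nM, with an expected range of 2500 nM to 30000 nM.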

Compound 3, half-maximal inhibitory concentration: > 100000 nM
Compound 3: no number, only a limit; the forecaster's own chance of this, stated with the estimate: 8%; middle value at least 11-fold (1.04 log units) away from the limit.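

In this assay compound 3 reaches only a limit, not a number: the limit of > 100000 nM in this assay, at which 1 of the 3 values shown sits.

Exchanging the whole 3,4-dihydroxyphenyl for the new group of 9 heavy atoms, on a double-bonded chain carbon bound to a double-bonded ring carbon, gives an at least 19-fold higher number from compound 1 to compound 3 (1.28 log units; beyond the scatter), a large step, against only a 2.4-fold higher number from compound 1 to compound 2 (0.39 log units; beyond the scatter) for the change of nitro in place of hydroxy. This place in the series therefore does not take every aromatic group alike: the earlier pair showed a modest shift, whereas this exchange leaves no number to read in this assay.

Because the whole group changes at once, the compounds shown cannot separate the loss of the 3,4-dihydroxyphenyl from the entry of the new group, and they do not tell how far past its limit compound 3 lies. A plain phenyl or a methoxyphenyl in the same place would bear on the first of these questions, by showing whether a six-membered aromatic ring of carbon only still gives a readable number without the two hydroxy groups.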